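Compound 3 and Its 2-Chlorophenyl Counterpart, Compound 4

The compounds below may be only part of what the source reports. "The series", "measured", "known", "first", "only" and "open" are said of these compounds alone.

Of the compounds shown here, three have been measured so far. In an ADME assay on Caco-2 cells (Homo sapiens) for permeability, in the apical to basolateral direction, at pH 7.4 (a higher number here means that the compound crosses the layer faster, a lower number that the compound crosses the layer more slowly), compound 1 `Cc1ccc2[nH]c(C(=O)N[C@H]3CN(S(=O)(=O)c4ccccc4)C[C@@H]3C(=O)N[C@@H]3CCCN(C)C3)cc2c1` gives 0.76 10^-6 cm/s while compound 2 `Cc1ccc2[nH]c(C(=O)N[C@H]3CCN(S(=O)(=O)c4ccccc4Cl)C[C@@H]3C(=O)N[C@H]3CCCN(C)C3)cc2c1` gives 0.27 10^-6 cm/s and compound 3 `Cc1oc(-c2ccc(Cl)cc2)nc1C(=O)N[C@H]1CN(S(=O)(=O)c2ccccc2)C[C@@H]1C(=O)N[C@H]1CCCNC1` gives 0.14 10^-6 cm/s as its reading. Compound 3 therefore stands within the scatter of compound 2, while compound 1 lies beyond the scatter from it with the higher number. These three compounds differ from one another in more than one place, so their numbers do not isolate the effect of any single group.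

The unmeasured compound 4 `Cc1oc(-c2ccccc2Cl)nc1C(=O)N[C@H]1CN(S(=O)(=O)c2ccccc2)C[C@@H]1C(=O)N[C@H]1CCCNC1` has the same atoms as compound 3, joined differently. The change is 2-chlorophenyl in place of 4-chlorophenyl on an aromatic carbon and it puts 2-chlorophenyl in place of 4-chlorophenyl on an aromatic carbon of the five-membered aromatic ring with 1 nitrogen and 1 oxygen. Among the compounds with values here, no measured pair shows what such a swap does in this assay and no direction can be favoured from these data. The expected step of a 1.1-fold higher number from compound 3 to compound 4 (0.06 log units; within the scatter) is therefore none beyond the scatter. The estimate stays close to compound 3 at 0.14 10^-6 cm/s as the nearest measured structure. In this assay compound 4 is estimated at 0.16 10^-6 cm/s within an expected range from 0.06 10^-6 cm/s to 0.4 10^-6 cm/s for a single measurement.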

Compound 4, apparent permeability in the Caco-2 assay: 0.13 10^-6 cm/s
Estimate against measurement, compound 4: 1.2-fold (0.09 log units) above, and the stated range covers the measured number.
By their numbers in the Caco-2 assay, from the lowest: compounds 4, 3 and 2 (each within the scatter of the next, the first and the last beyond it); then compound 1.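

Within the data shown here, this is the first step that changes a single place, and in the Caco-2 assay putting 2-chlorophenyl in place of 4-chlorophenyl, on an aromatic carbon of the five-membered aromatic ring with 1 nitrogen and 1 oxygen, gives a 1.1-fold lower number from compound 3 to compound 4 (0.03 log units; within the scatter), so the two groups cannot be told apart by this read-out at this position. The swap is not silent, however, since compound 4 is the more polar of the pair in a physicochemical assay for lipophilicity, measured as octanol-water partition, at pH 7.4; a lower number here means a more polar compound, a higher number a more lipophilic compound: the measured distribution coefficient of compound 3, 2, and of compound 4, 1.6, a number 0.40 log units lower (beyond the scatter) In the physicochemical assay compound 3 gives 2 and compound 4 gives 1.6. A shift of that size in the distribution coefficient therefore came here without a readable shift in the Caco-2 assay, so this one pair gives no sign that the reading follows the partition value when only the place of the chlorine changes.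

The compounds shown leave open whether an amine or a carboxylic acid in place of the chlorine would move the reading in the Caco-2 assay beyond the scatter. They also leave open whether the same swap would read alike on the core of compound 1 or of compound 2, which carry other groups elsewhere.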